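A few compounds are considered here, and "the series" means these few. Any claim that something is new, unique, unknown or untested is made for them only; others in the source may bear on it.

Among the compounds with values here, in a functional assay on SF-268 cells (Homo sapiens) for cytotoxicity (a higher number here means a weaker inhibitor, a lower number a stronger inhibitor), three compounds have numbers so far. Compound 1 `Oc1cc(O)cc(CCCCC/C=C/CCCCCCCc2cc(O)cc(O)c2)c1` gives 30600 nM, compound 3 `COc1cc(O)cc(CCCCCCC/C=C/CCCCCc2cc(O)cc(O)c2)c1` gives 30200 nM, and compound 2 `Oc1cc2cc(c1)Oc1c(O)cc(cc1O)[C@H](O)CCCCCCCCCCCCC2` gives 32100 nM, which places compound 2 within the scatter of both others. Compound 4 `Oc1cc2cc(c1)Oc1c(O)cc(cc1O)CCCCCCCCCCCCCC2` differs from compound 2 by a single change: hydrogen in place of hydroxy on a saturated ring carbon. Within the data shown here, the only measured step, a 1.0-fold lower number from compound 1 to compound 3 (0.01 log units; within the scatter), is methyl in place of hydrogen on an oxygen on an aromatic ring, so it bears on this change only loosely. Among the measured compounds shown here, compound 2, at 32100 nM, anchors the expectation, and no measured step removes a hydroxy, so no shift beyond the scatter is expected in this assay. The expected step is a 1.1-fold lower number from compound 2 to compound 4 (0.03 log units; within the scatter). For compound 4 the estimated value is 30000 nM, with a range of 15000 nM to 60000 nM.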

Compound 4, half-maximal inhibitory concentration: 32700 nM
The estimate for compound 4 lay 1.1-fold (0.04 log units) below the measured number; low and high end bracket the measured number.
By their numbers in this assay, from the lowest: compounds 3, 1, 2 and 4 (each within the scatter of the next).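

In this assay, a 1.0-fold higher number from compound 2 to compound 4 (0.01 log units; within the scatter) shows that hydroxy on this saturated ring carbon of the 22-membered ring can give way to hydrogen without a shift beyond the scatter. Within the data shown here, the earlier compounds offered only a step on an oxygen on an aromatic ring, so this is the first reading of a change at this saturated ring carbon. No evidence at hand bears on this result.

The compounds shown leave open whether an amine or a carboxylic acid on this saturated ring carbon would move the number beyond the scatter.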